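This account rests on a few compounds, and the source may have more. Where it says the series, first, only, none or still open, it means among the compounds named here.

Of the compounds shown here, two have so far been measured in an assay on isolated protein for inhibition of Aromatase (Homo sapiens), read by fluorescence, tested at 1 uM; on this read-out lower numbers stand for less inhibition and higher numbers for more inhibition at the one concentration tested (going by the name of the read-out). Compound 1, `Ic1ccc(-n2ccc3ccncc32)cc1`, gives 26% in this assay. Compound 2, `CN1CCN(c2cc(Oc3cccnc3)ccc2C#N)CC1`, gives 8% in this assay. Compound 1 therefore stands highest of the two numbers, and compound 2, its nearest neighbour, lies lower by a gap that is beyond the usual scatter of repeated measurements.

Compound 3, `NC(=O)c1ccc(-n2ccc3ccncc32)cc1`, has not yet been measured in this assay. It differs from compound 1 in a single place: carbamoyl in place of iodo on an aromatic carbon. The iodo leaves and the carbamoyl enters, and the carbamoyl brings a hydrogen-bond donor and a hydrogen-bond acceptor where the iodo carried none.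

Among the compounds with values here, no pair of measured compounds that differ in one place is available, so nothing yet shows how large a change of this kind tends to be in this assay. The expected step is a number 8 percentage points lower from compound 1 to compound 3 (within the scatter), a modest downward movement that may well stay within the scatter. Compound 3 is expected to give 18%, with a likely range from 4% to 40%.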

Compound 3, a percentage reported as inhibition, at one concentration (the size of the read-out at that concentration, not a potency): 60%
Beside the measured number, compound 3's estimate is 42 percentage points below it; measured number outside the range, above it.
By their numbers in this assay, from the lowest: compound 2; then compound 1; then compound 3.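

In this assay, the aromatic carbon para to the group of 9 heavy atoms proves to be a place where a single change matters: carbamoyl in place of iodo gives a number 34 percentage points higher from compound 1 to compound 3 (beyond the scatter), and this step is large. Within the data shown here, until now no two compounds differed in only one place, so nothing showed how far the number could move with the rest of the structure held fixed; here, changing this one group while the shared core stays the same moves it well beyond the scatter. The data offer nothing that explains why this swap has so large an effect.

On these data alone, a single step cannot separate the loss of the iodo from the gain of the carbamoyl, so it remains open whether the number follows the hydrogen-bond donor, the hydrogen-bond acceptor, or neither of them. A plain hydrogen, a carboxylic acid, an amine or a methyl ester on the same aromatic carbon would help to pull these possibilities apart, and the same holds for moving the carbamoyl elsewhere on the ring.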